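Swapping Isopropyl for Bromo on a Urea Scaffold

The source may hold more compounds than are shown below. What is called first, only, known or untested is meant among the compounds shown, and "the series" means these compounds.

Three ureas have been measured in an ADME assay on the whole organism with Oryza sativa as the target, tested at 1 uM; on this read-out lower numbers stand for a stronger effect and higher numbers for a weaker effect at the one concentration tested. Compound 1 `CC(C)c1cccc(NC(=O)N[C@H](C)c2ccccc2)c1` gives 61%, compound 2 `CC(C)c1cccc(NC(=O)N[C@@H](C)c2ccccc2)c1` gives 84%, and compound 3 `C[C@@H](NC(=O)Nc1ccccc1F)c1ccccc1` gives 95%. Compound 2 therefore stands second highest of the three numbers, with compound 3 above it and compound 1 below it. Going by the values given here, the only step that can be read directly is a number 23 percentage points higher from compound 1 to compound 2 (beyond the scatter), and it rests on the fact that compounds 1 and 2 differ only in the configuration as drawn alone; no other pair differs in a single place.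

Compound 4 `C[C@H](NC(=O)Nc1cccc(Br)c1)c1ccccc1` has not yet been measured. It differs from compound 2 by bromo in place of isopropyl on an aromatic carbon. Among the compounds with values here, none of the measured steps concerns such an exchange on the aromatic ring, so the only anchor is the number for compound 2 itself, and no step beyond the scatter is predicted in this assay. The value of compound 4 is estimated at 84%, between 65% and 97%, which would mean an expected step of no change at the digits printed from compound 2 to compound 4 (within the scatter).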

Compound 4, a percentage reported as activity, at one concentration (the size of the read-out at that concentration, not a potency): 100%
For compound 4 the middle estimate is 16 percentage points below the measured one; the whole stated range lies below it.
By their numbers in this assay, from the lowest: compound 1; then compound 2; then compounds 3 and 4 (each within the scatter of the next).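

In this assay, the exchange of isopropyl for bromo on an aromatic carbon, meta to a large group, is not a silent one: it gives a number 16 percentage points higher from compound 2 to compound 4 (beyond the scatter), and on this read-out a higher number stands for a weaker effect. Until now, only a change of configuration at the chain carbon had been seen to move the number, and this pair shows that a change on the aromatic ring can move it as well. Going by these compounds alone, nothing given here explains this step, since the only evidence available concerns configuration and has no bearing on this exchange.

The compounds shown leave open how a methyl, a chloro or a methoxy group would read at this place on the ring. They also leave open whether the same exchange would give a similar step with the configuration drawn in compound 1.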